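Triazolopyrimidine series: replacing the pyrrolidine ring

The compounds below may be only part of what the source reports. "The series", "measured", "known", "first", "only" and "open" are said of these compounds alone.

Measured so far:
compound 1, `CCCC(C)Nc1nc(C)nc2c1nnn2-c1c(C)cc(C)cc1C`: 7.1 nM
compound 2, `Cc1nc(N2CCCC2)c2nnn(-c3ccc(C(C)C)cc3Br)c2n1`: 194 nM

In an in vitro assay on 293-EBNA cells for binding affinity to corticotropin-releasing factor receptor 1 (Homo sapiens) (on this read-out lower numbers stand for stronger inhibition and higher numbers for weaker inhibition), compound 2 gives 194 nM, the highest of the two numbers, while compound 1 gives 7.1 nM, a gap beyond the scatter. Compound 3, `CCCC(CN(C)C)Nc1nc(C)nc2c1nnn2-c1ccc(C(C)C)cc1Br`, keeps the aryl group of compound 2 and differs in one place: a group of 9 heavy atoms (7 carbon, 2 nitrogen; no ring) in place of a group of 5 heavy atoms (4 carbon, 1 nitrogen; one five-membered non-aromatic ring with 1 hetero atom), on an aromatic carbon, on an aromatic carbon of the shared core, next to the ring nitrogen. Within the data shown here, no step of this exact kind has been measured. Compound 1 carries an open-chain amine of this type and gives the lower number, so compound 3 is expected to move toward it, a step of a 9.7-fold lower number from compound 2 to compound 3 (0.99 log units; beyond the scatter) in this assay. Compound 3 is estimated at 20 nM, within 5 nM to 80 nM.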

Compound 3, inhibition constant: 38.7 nM
Beside the measured number, compound 3's estimate is 1.9-fold (0.29 log units) below it; the measured number falls inside the stated range.
By their numbers in this assay, from the lowest: compound 1; then compound 3; then compound 2.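

In this assay, a ring is not needed on this aromatic carbon of the shared core: exchanging pyrrolidin-1-yl for the open-chain amine gives a 5.0-fold lower number from compound 2 to compound 3 (0.70 log units; beyond the scatter) on the same aryl group. This change also adds a hydrogen-bond donor, so ring loss, the donor and the larger group arrive together and cannot be separated here. No data bearing on the reason for this step are available.

On these data alone, whether a piperidine ring or a morpholine ring would be tolerated here remains open. So does the effect of a primary amine at the chain end.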